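Cinnamoyl sulfonamides: fluoro for methyl, second occurrence

The source may report more compounds than this note shows. Statements on the series, on what has been measured and on what is new or still open speak of the compounds shown alone.

Compound 1 `Cc1ccc(S(=O)(=O)NC(=O)/C=C/c2ccccc2)cc1` gives 13.8 ug/mL
Compound 2 `O=C(/C=C/c1ccccc1)NS(=O)(=O)c1ccc(F)cc1` gives 2.1 ug/mL
Compound 3 `COc1ccc(/C=C/C(=O)NS(=O)(=O)c2ccc(C)cc2)cc1` gives 12.2 ug/mL

All three were run in a functional assay on B16-F10 cells (Mus musculus) for antiproliferative activity, read by ELISA and MTT assay, with a stated time of 48 h; a higher number here means a weaker inhibitor, a lower number a stronger inhibitor. Compound 1 and compound 3 share one core and differ by methoxy in place of hydrogen on an aromatic carbon; the step of a 1.1-fold lower number from compound 1 to compound 3 (0.05 log units; within the scatter) is within the scatter, so the two values are read as the same. Compound 2 differs from compound 1 by fluoro in place of methyl on an aromatic carbon, and here the step of a 6.6-fold lower number from compound 1 to compound 2 (0.82 log units; beyond the scatter) is beyond the scatter.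

Compound 4 `COc1ccc(/C=C/C(=O)NS(=O)(=O)c2ccc(F)cc2)cc1` is not yet measured. It differs from compound 3 by fluoro in place of methyl on an aromatic carbon. The place of this change is described in the same words as for the change from compound 1 to compound 2, so the two are taken as the same change, made on two cores that differ only by the methoxy noted above. Within the data shown here, the one measured instance of this change gave a 6.6-fold lower number from compound 1 to compound 2 (0.82 log units; beyond the scatter), and the methoxy itself did nothing beyond the scatter between compound 1 and compound 3. Among the measured compounds shown here, the expectation for compound 4 is therefore a step of about a 5.3-fold lower number from compound 3 to compound 4 (0.72 log units; beyond the scatter), resting on the single measured step of a 6.6-fold lower number from compound 1 to compound 2 (0.82 log units; beyond the scatter) and on the near-equal values of compound 1 and compound 3. With one precedent only, the range is kept wide. Compound 4 is estimated to give 2.3 ug/mL in this assay, with a plausible span from 1 ug/mL to 6 ug/mL.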

Compound 4, half-maximal inhibitory concentration: 5.1 ug/mL
The estimate for compound 4 lay 2.2-fold (0.35 log units) below the measured number; low and high end bracket the measured number.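

In this assay, fluoro in place of methyl again gives a lower number on the methoxy core, with a 2.4-fold lower number from compound 3 to compound 4 (0.38 log units; beyond the scatter) as the step, but the size does not carry over unchanged from the core without methoxy: the same change on two cores in this assay, a 6.6-fold lower number (0.82 log units; beyond the scatter) from compound 1 to compound 2 and a 2.4-fold lower number (0.38 log units; beyond the scatter) from compound 3 to compound 4, 2.7-fold (0.44 log units) apart, beyond the scatter of two such steps

Read the other way round, methoxy in place of hydrogen makes no difference beyond the scatter on the methyl-bearing pair, yet on the fluoro-bearing pair it gives a 2.4-fold higher number from compound 2 to compound 4 (0.39 log units; beyond the scatter) as the step, so the two changes do not act independently in these four compounds: the same change on two cores in this assay, a 1.1-fold lower number (0.05 log units; within the scatter) from compound 1 to compound 3 and a 2.4-fold higher number (0.39 log units; beyond the scatter) from compound 2 to compound 4, 2.7-fold (0.44 log units) apart, beyond the scatter of two such steps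

The direction of the fluoro-for-methyl change therefore held on both cores while its size did not, which argues for carrying the direction forward and against carrying a fixed size; with only these two cores, this gives no general rule for the series and no reason for the gap.

Still open, going by these compounds, is whether chloro or nitrile in the place of the fluoro would show the same dependence on the methoxy group. Also open, on these data alone, is whether a hydroxy group or an amine in the place of the methoxy would shrink the fluoro-for-methyl step in the same way or leave it at the size seen on the core of compound 1.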